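This account rests on a few compounds, and the source may have more. Where it says the series, first, only, none or still open, it means among the compounds named here.

Compound 2 `Cc1ccc2cc([C@H](C)Nc3ncnc4[nH]cnc34)c(-c3ccccc3)c(=O)n2c1` has no number to stand on in an ADME assay on microsomes from liver (Homo sapiens), read by LC-MS, using NADPH, with a stated time of 30 min, tested at 1 uM; on this read-out higher numbers stand for a more stable compound and lower numbers for a less stable compound: its entry reads "not determined" (no result reported), and so it cannot be placed against any other compound on this read-out. The same holds for compound 3 `Cc1ccc2cc([C@H](C)Nc3ncnc(N)c3C#N)c(-c3ccccc3)c(=O)n2c1`, which carries a nitrile and an amino group on its heteroaromatic ring and likewise shows "not determined" (no result reported) in this assay. Going by the values given here, the one compound of the set that does give a figure is compound 1 `C[C@H](Nc1ncnc2[nH]cnc12)c1cc2ccccn2c(=O)c1-c1ccccc1`, which shares the bicyclic core and the phenyl group of compound 2 but lacks the methyl group; in this assay compound 1 gives 100%.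

Compound 4 `C[C@H](Nc1ncnc2[nH]cnc12)c1cc2ccc(F)cn2c(=O)c1-c1ccccc1` is reached from compound 2 through (fluoro in place of methyl on an aromatic carbon), that is, fluoro in place of methyl on an aromatic carbon. Among the compounds with values here, with no number for compound 2, no step from compound 2 to compound 4 can be computed, and no pair of measured compounds in this assay differs in a single place, so no measured step guides the expectation. What is known is that compound 1 gives 100% in this assay, and compound 4 differs from compound 1 only in the fluoro group. On that footing compound 4 is expected to remain at the stable end, with an estimated 94% in this assay, the range running from 75% to 100%.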

Compound 4, percent of the compound remaining: 98%
Beside the measured number, compound 4's estimate is 4 percentage points below it, and the stated range covers the measured number.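

In this assay the set now holds its first readable step, a number 2 percentage points lower from compound 1 to compound 4 (within the scatter), and it concerns a single place: compound 4 carries a fluoro group where compound 1 has a hydrogen, on an aromatic carbon two atoms from the ring nitrogen. The earlier compounds shown here gave one figure and nothing to set it against, whereas this pair shows that the position can carry a fluoro group with no difference beyond the scatter on this read-out, so compound 1 and compound 4 cannot be told apart here. Nothing among the data shown accounts for this result, which stands as an observation only.

Going by these compounds, the step from methyl to fluoro cannot be read, since compound 2 has no number, so how a methyl group at this position fares on this read-out remains open, as does the standing of compound 3. Also open, on these data alone, is whether the position would take something other than a fluoro group equally well, such as a methoxy group, an amine or a longer chain, since only hydrogen and fluoro have values here.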